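A few compounds are considered here, and "the series" means these few. Any claim that something is new, unique, unknown or untested is made for them only; others in the source may bear on it.

Compound 2 `COc1ccc(S(=O)(=O)N2CCc3cccc(NC(=O)c4cccs4)c32)cc1` gives, in a functional assay on KB cells (Homo sapiens) for cytotoxicity (on this read-out lower numbers stand for stronger inhibition and higher numbers for weaker inhibition), a value of 47 nM. Of the two numbers in hand this is the lowest; the other belongs to compound 1 `COc1ccc(C(=O)Nc2cccc3c2N(S(=O)(=O)c2ccc(OC)cc2)CC3)cc1`, which in this assay gives 2600 nM. Among the measured compounds shown here, the single measured step, a 55-fold lower number from compound 1 to compound 2 (1.74 log units; beyond the scatter), came from thiophen-2-yl in place of 4-methoxyphenyl on a carbonyl carbon. Compound 3 `COc1ccc(S(=O)(=O)N2CCc3cccc(NC(=O)c4ccco4)c32)cc1` alters that same position once more: furan-2-yl in place of thiophen-2-yl on a carbonyl carbon. For the measured compounds named here, no measured step exchanges one five-membered aromatic ring with one hetero atom for another; the recorded step replaced a six-membered ring with a five-membered one, so it bears on the present change only loosely. With the rings leaving and entering differing only in sulfur against oxygen, the expected step in this assay is small, a 1.7-fold higher number from compound 2 to compound 3 (0.23 log units; within the scatter), quite possibly within the scatter, leaning toward a somewhat higher number. Compound 3 is therefore estimated at 80 nM, with a range from 25 nM to 250 nM.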

Compound 3, half-maximal inhibitory concentration: 9.6 nM
Compound 3: middle estimate off by 8.3-fold (0.92 log units), on the high side; the measured number lies below the stated range.
By their numbers in this assay, from the lowest: compound 3; then compound 2; then compound 1.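

In this assay the exchange of one five-membered aromatic ring for another on the carbonyl carbon gives a 4.9-fold lower number from compound 2 to compound 3 (0.69 log units; beyond the scatter) and is therefore not a silent swap. This position separates furan-2-yl from thiophen-2-yl, although the two groups match in the heavy-atom and hydrogen-bond counts and differ only in oxygen against sulfur. Set against the 4-methoxyphenyl group, furan-2-yl gives a 270-fold lower number from compound 1 to compound 3 (2.43 log units; beyond the scatter) and widens the span seen at this position so far. Nothing at hand accounts for the gap between furan-2-yl and thiophen-2-yl.

Open, on these data alone, is whether a saturated tetrahydrofuran-2-yl ring or a pyridin-2-yl ring on the same carbonyl carbon would keep the number of compound 3. Also open, as far as these compounds go, is how a methyl or a carboxylic acid on the furan ring would shift it.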